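Working notes on the substituent at the triazole-type nitrogen

A few compounds are considered here, and "the series" means these few. Any claim that something is new, unique, unknown or untested is made for them only; others in the source may bear on it.

Measured compounds:
compound 1, `CN(CCNCc1cn(Cc2nc3cc(Cl)ccc3[nH]2)nn1)CCNc1ccnc2cc(Cl)ccc12`, in a functional assay on NCI-H460 cells (Homo sapiens) for antiproliferative activity, read by sulforhodamine B assay, with a stated time of 72 h (a higher number here means a weaker inhibitor, a lower number a stronger inhibitor), compound 1 gives 59000 nM
compound 2, `CN(CCNCc1cn(-c2nc3ccccc3[nH]2)nn1)CCNc1ccnc2cc(Cl)ccc12`, in this assay compound 2 gives 33000 nM

Going by the values given here, compound 2 holds the lowest of the two numbers, but the only measured step, a 1.8-fold lower number from compound 1 to compound 2 (0.25 log units; within the scatter), lies within the scatter, so the two compounds are not separated. Compound 3, `CN(CCNCc1cn(CCC(=O)Nc2ccccn2)nn1)CCNc1ccnc2cc(Cl)ccc12`, differs from compound 2 by 2-((pyridin-2-yl)carbamoyl)ethyl in place of 1H-benzimidazol-2-yl on an aromatic nitrogen. The measured step changed the group at the same aromatic nitrogen and moved nothing beyond the scatter; it bears on this change only loosely, since here an aromatic ring gives way to an open-chain amide. No step beyond the scatter is expected. Compound 3 is estimated at 35000 nM (range 12000 nM to 100000 nM), meaning a 1.1-fold higher number from compound 2 to compound 3 (0.03 log units; within the scatter).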

Compound 3, half-maximal inhibitory concentration: > 200000 nM
Compound 3 ended at the assay's limit; the forecaster's own chance of this, stated with the estimate: 15%; middle value at least 5.7-fold (0.75 log units) away from the limit.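

In this assay compound 3 stands at a limit of the assay, not at a number: the limit of > 200000 nM in this assay, at which 1 of the 3 values shown sits.

At this aromatic nitrogen, 2-((pyridin-2-yl)carbamoyl)ethyl in place of 1H-benzimidazol-2-yl gives an at least 6.0-fold higher number from compound 2 to compound 3 (0.78 log units; beyond the scatter), and the same group read as ((pyridin-2-yl)carbamoyl)methyl in place of 5-chloro-1H-benzimidazol-2-yl gives an at least 3.3-fold higher number from compound 1 to compound 3 (0.53 log units; beyond the scatter). The group here can therefore shift the read-out beyond the scatter, which the earlier pair did not show.

Going by these compounds, the full size of the shift stays open. Also open, on these data alone, is whether it follows the amide or the pyridine ring, which a phenyl amide or a carboxylic acid on the same chain would help separate.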